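Amine swap on the thiocarbonyl carbon: compound 3 expected

The compounds below may be only part of what the source reports. "The series", "measured", "known", "first", "only" and "open" are said of these compounds alone.

Two measured compounds share one core. Compound 1 `CC1CCCCN1C(=S)SCc1ccc(C(=O)Nc2ccccc2N)cc1` in a functional assay on MGC-803 cells (Homo sapiens) for antiproliferative activity, read by CCK-8 assay, with a stated time of 72 h, tested at 8 uM (a higher number here means a stronger effect of the compound at the concentration tested, a lower number a weaker effect), gives 86.9%. Compound 2 `CN(Cc1ccncc1)C(=S)SCc1ccc(C(=O)Nc2ccccc2N)cc1` in this assay gives 83.2%. Of the two numbers, compound 2 gives the lower and compound 1 is the nearest, the gap being within the scatter, so no order between them is claimed. Compound 3 `Nc1ccccc1NC(=O)c1ccc(CSC(=S)N2CCCC2)cc1` is not yet measured; it differs from compound 2 as follows: pyrrolidin-1-yl in place of methyl((pyridin-4-yl)methyl)amino on a thiocarbonyl carbon. Going by the values given here, only one measured step bears on this change: a number 3.7 percentage points lower from compound 1 to compound 2 (within the scatter), which also exchanged one amino group for another on the thiocarbonyl carbon and stayed within the scatter. With that single precedent, the expected step of a number 0.8 percentage points higher from compound 2 to compound 3 (within the scatter) is none beyond the scatter. Compound 3 is therefore estimated at 84% in this assay, with a range from 72% to 92%, the width reflecting that one step is a thin basis.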

Compound 3, a percentage reported as inhibition, at one concentration (the size of the read-out at that concentration, not a potency): 83.4%
Estimate against measurement, compound 3: 0.6 percentage points above, and the stated range covers the measured number.
By their numbers in this assay, from the lowest: compounds 2, 3 and 1 (each within the scatter of the next).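

In this assay, the step of a number 0.2 percentage points higher from compound 2 to compound 3 (within the scatter) and the step of a number 3.5 percentage points lower from compound 1 to compound 3 (within the scatter) show that pyrrolidin-1-yl on the thiocarbonyl carbon reads the same, within the scatter, as both earlier amino groups. Compound 3 lacks the six-membered aromatic ring and the hydrogen-bond acceptor of methyl((pyridin-4-yl)methyl)amino, so neither is needed to keep the read-out at this single concentration, at least among these three compounds. No available data explain why the read-out stays flat across these changes.

Going by these compounds, whether morpholin-4-yl, piperazin-1-yl with its free ring amine, or an open-chain diethylamino group on the same carbon would also stay within the scatter remains open. Also open, on these data alone, is whether compounds 1, 2 and 3 would separate into stronger and weaker effects at other concentrations.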